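A few compounds are considered here, and "the series" means these few. Any claim that something is new, unique, unknown or untested is made for them only; others in the source may bear on it.

Working notes on the series. Among the compounds with values here, compound 2 `Clc1ccc(CSc2nnc(-c3ccncc3)n2-c2ccccc2)cc1` gives 13300 nM in a functional assay on MCF7 cells (Homo sapiens) for inhibition, read by MTT assay, with a stated time of 48 h (on this read-out higher numbers stand for weaker inhibition and lower numbers for stronger inhibition), the lower of the two numbers so far; compound 1 `Clc1ccccc1CSc1nnc(-c2ccncc2)n1-c1ccccc1` gives 18100 nM, and the step of a 1.4-fold lower number from compound 1 to compound 2 (0.13 log units; within the scatter) lies within the scatter. Compound 3 `O=[N+]([O-])c1cccc(CSc2nnc(-c3ccncc3)n2-c2ccccc2)c1` differs from compound 2 by 3-nitrophenyl in place of 4-chlorophenyl on a saturated chain carbon bound to a sulfur. Within the data shown here, the only measured step touches the same site but swaps chlorophenyl isomers, so it bears on the change only loosely, and it was small. For compound 3 the expected step is therefore a 1.0-fold lower number from compound 2 to compound 3 (0.01 log units; within the scatter), none beyond the scatter. Compound 3 is estimated at 13000 nM, within 4500 nM to 38000 nM.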

Compound 3, half-maximal inhibitory concentration: 18300 nM
Compound 3: the middle estimate sits 1.4-fold (0.15 log units) below what was measured; the measured number falls inside the stated range.
By their numbers in this assay, from the lowest: compounds 2, 1 and 3 (each within the scatter of the next).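

In this assay, swapping a chlorophenyl for 3-nitrophenyl on a saturated chain carbon bound to a sulfur gives no step beyond the scatter, whether from the 4-chlorophenyl (a 1.4-fold higher number from compound 2 to compound 3 (0.14 log units; within the scatter)) or from the 2-chlorophenyl (a 1.0-fold higher number from compound 1 to compound 3 (0.00 log units; within the scatter)). This position therefore accepts a group with hydrogen-bond acceptors and more heavy atoms with no readable change in the number. No supporting data bear on why these numbers stay level. From the compounds shown here alone, whether an amine, a carboxylic acid or a longer chain at this position would give a step beyond the scatter stays open, as does any change elsewhere on the shared core.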